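The source may report more compounds than this note shows. Statements on the series, on what has been measured and on what is new or still open speak of the compounds shown alone.

Measured in an ADME assay on HepG2 cells (Homo sapiens) for cytotoxicity; a higher number here means that more compound is tolerated, a lower number that less compound is tolerated:

- Compound 1 `CSc1cccc(N2C(=O)CN(c3ccccc3)CC2(C)C(=O)NC2CCCC2)c1`: > 50000 nM
- Compound 2 `CSc1cccc(N2C(=O)CN(c3cccc(C(F)(F)F)c3)CC2C(=O)NC2CCCC2)c1`: 20000 nM

Only compound 2 gives an actual number in this assay, 20000 nM, so it stands alone as a measured reference point. Compound 1 has no number, and its > 50000 nM is a limit of the assay.

The next compound to be tested is compound 3 `CSc1cccc(N2C(=O)CN(c3cccnc3)CC2C(=O)NC2CCCC2)c1`. It has pyridin-3-yl in place of the 3-(trifluoromethyl)phenyl of compound 2, on an amine nitrogen in a ring: pyridin-3-yl in place of 3-(trifluoromethyl)phenyl on an amine nitrogen in a ring. The rest of the structure is unchanged.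

Among the compounds with values here, no measured step in this small set shows what such an exchange does. The expectation therefore rests only on compound 2 at 20000 nM and on the structural change. A modest step in this assay is expected, towards more compound being tolerated, though it may not clearly exceed the usual scatter. The expected step is a 1.8-fold higher number from compound 2 to compound 3 (0.24 log units; within the scatter). For compound 3 the estimated value is 35000 nM, with an expected range from 15000 nM to 50000 nM.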

Compound 3, half-maximal cytotoxic concentration: > 50000 nM
Compound 3: a limit, no number (the forecaster's own chance of this, stated with the estimate: 40%); at least 1.4-fold (0.15 log units) between middle value and limit.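

Placing pyridin-3-yl in place of 3-(trifluoromethyl)phenyl on the amine nitrogen in the ring gives, in this assay, an at least 2.5-fold higher number from compound 2 to compound 3 (0.39 log units; beyond the scatter), so this position can shift the read-out by more than the usual scatter. Compound 3 gives > 50000 nM, which is a limit of the assay and not a number. The step can therefore be read only as a lower bound, and its full size stays unknown, because the read-out of compound 3 ends at a limit: the limit of > 50000 nM in this assay, at which 2 of the 3 values shown sit.

From the compounds shown here alone, it remains open whether the step comes from losing the trifluoromethyl group or from bringing in the ring nitrogen of pyridin-3-yl, and what a plain phenyl, a 3-chlorophenyl or a pyridin-4-yl group would do at this position on the core of compound 2. Within the data shown here, compound 1 carries a phenyl group on this nitrogen but also differs from compound 2 in a second place, so that pair gives no step that can be read.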